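This account rests on a few compounds, and the source may have more. Where it says the series, first, only, none or still open, it means among the compounds named here.

Three compounds have been measured in a functional assay on NCI-H460 cells (Homo sapiens) for cytotoxicity, read by MTT assay, with a stated time of 72 h; on this read-out higher numbers stand for weaker inhibition and lower numbers for stronger inhibition:
compound 1 `COc1cc2c(Oc3ccc(NC(=O)c4nn(-c5ccccc5Br)c(=O)c5ccccc45)cc3F)ccnc2cc1OCCCN1CCCC1` gives 320 nM;
compound 2 `COc1cc2c(Oc3ccc(NC(=O)c4nn(-c5ccccc5F)c(=O)c5ccccc45)cc3F)ccnc2cc1OCCCN1CCN(C)CC1` gives 230 nM;
compound 3 `COc1cc2c(Oc3ccc(NC(=O)c4nn(-c5ccc(Br)cc5)c(=O)c5ccccc45)cc3F)ccnc2cc1OCCCN1CCN(C)CC1` gives 250 nM.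

Compound 3 stands second highest of these three numbers; compound 2 lies nearest and compound 1 furthest, and both gaps are within the scatter, so no order among the three can be claimed. Compound 4 `COc1cc2c(Oc3ccc(NC(=O)c4nn(-c5ccccc5Br)c(=O)c5ccccc45)cc3F)ccnc2cc1OCCCN1CCN(C)CC1` is obtained from compound 3 by exchanging the bromophenyl group on the aromatic nitrogen: 2-bromophenyl in place of 4-bromophenyl on an aromatic nitrogen. Among the compounds with values here, the only measured one-place step, a 1.1-fold higher number from compound 2 to compound 3 (0.04 log units; within the scatter), exchanged one halogenated phenyl for another at the same aromatic nitrogen and stayed within the scatter. Compound 1 already carries the 2-bromophenyl but differs elsewhere, and its value sits within the scatter of compound 3. All three numbers lie close together, and no change on this phenyl ring has yet moved this assay beyond the scatter. The expected step, a 1.1-fold higher number from compound 3 to compound 4 (0.03 log units; within the scatter), is therefore small. Compound 4 is estimated at 270 nM, within a range from 140 nM to 520 nM.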

Compound 4, half-maximal inhibitory concentration: 290 nM
For compound 4 the middle estimate is 1.1-fold (0.03 log units) below the measured one; the measured number falls inside the stated range.
By their numbers in this assay, from the lowest: compounds 2, 3, 4 and 1 (each within the scatter of the next).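

In this assay, within the data shown here, shifting the bromine on this phenyl ring, with 2-bromophenyl in place of 4-bromophenyl on the aromatic nitrogen, gives a step within the scatter (a 1.2-fold higher number from compound 3 to compound 4 (0.06 log units; within the scatter)), so this is the first view of the bromine's place on the ring alone. Compound 4 also allows two further single changes: bromo in place of fluoro on an aromatic carbon (a 1.3-fold higher number from compound 2 to compound 4 (0.10 log units; within the scatter)) and 4-methylpiperazin-1-yl in place of pyrrolidin-1-yl on the saturated chain (a 1.1-fold lower number from compound 1 to compound 4 (0.04 log units; within the scatter)), and both stay within the scatter too. No supporting measurement is available to explain why these numbers stay so close.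

On these data alone, whether any change on this ring can move the number beyond the scatter remains open. An unsubstituted phenyl, or a phenyl carrying an amine or a carboxylic acid, would test this.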